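Adding a Methoxy Group to the Lowest Number So Far

This account rests on a few compounds, and the source may have more. Where it says the series, first, only, none or still open, it means among the compounds named here.

Three compounds share one core: a benzamide joined through a benzylic link to an aryl sulfonamide. Compound 1 `Cc1ccc(S(=O)(=O)NCc2ccc(CNC(=O)c3ccccc3)cc2)cc1` is the plain parent. In an assay on MDA-MB-231 cells for binding affinity to C-X-C chemokine receptor type 4 (Homo sapiens), read by immunofluorescence and microscopy, with stated times of 10 min and 30 min (on this read-out lower numbers stand for an effect already at smaller amounts and higher numbers for an effect only at larger amounts of compound), compound 1 gives > 1000 nM, which is a limit of the assay rather than a number (the limit of > 1000 nM in this assay, at which 1 of the 3 values shown sits). Compound 2 `Cc1ccc(S(=O)(=O)NCc2ccc(CNC(=O)c3ccc([N+](=O)[O-])cc3)cc2)cc1` carries a nitro group on the benzamide ring, and in this assay compound 2 gives 10 nM, a change of an at least 100-fold lower number from compound 1 to compound 2 (2.00 log units; beyond the scatter). Compound 3 `O=C(NCc1ccc(CNS(=O)(=O)c2ccccc2)cc1)c1ccccc1` instead lacks the methyl group on the sulfonyl ring, and in this assay compound 3 gives 1 nM, a change of an at least 1000-fold lower number from compound 1 to compound 3 (3.00 log units; beyond the scatter). Compound 3 therefore stands lowest among the two numbers shown, with compound 2 the nearest and beyond the scatter above it.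

Compound 4 `COc1cccc(C(=O)NCc2ccc(CNS(=O)(=O)c3ccccc3)cc2)c1` differs from compound 3 by methoxy in place of hydrogen on an aromatic carbon. Among the measured compounds shown here, no measured step repeats this change. On these data alone, the nitro step shows only that a substituent on this ring can move the number strongly, and it starts from a limit, so its true size is unknown. Compound 3 already sits very low, which leaves little room for a further drop. For compound 4 the expected step is a 3.0-fold higher number from compound 3 to compound 4 (0.48 log units; beyond the scatter). Compound 4 is estimated at 3 nM, within a range from 0.5 nM to 30 nM.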

Compound 4, effective concentration (reported as EC, without a stated level of effect): > 1000 nM
Compound 4: only a limit was reported; the forecaster's own chance of this, stated with the estimate: 5%; middle value at least 330-fold (2.52 log units) away from the limit.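

In this assay compound 4 gives > 1000 nM, which is a limit of the assay and not a number: the limit of > 1000 nM in this assay, at which 2 of the 4 values shown sit. On these data alone, the change from phenyl to 3-methoxyphenyl, at a place meta to a large group, therefore brings an at least 1000-fold higher number from compound 3 to compound 4 (3.00 log units; beyond the scatter), and how far the step truly reaches remains unknown. The earlier compounds shown here showed a group on this ring only pushing the number down, as in an at least 100-fold lower number from compound 1 to compound 2 (2.00 log units; beyond the scatter), whereas this single added methoxy pushes it up, so compound 4 goes against any rule that a group here lowers the number, although the two steps start from different compounds and involve different groups.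

What stays open is whether the loss belongs to the methoxy group itself or to the place it occupies, since the compounds shown offer no methoxy elsewhere on this ring to set beside compound 4. A hydroxyl, a fluorine or an amine at the same place on compound 3 would help to separate those two readings, and a longer chain such as ethoxy would show how the number responds to more atoms there.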